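Permeability of a triazine series: amide to urea step

A few compounds are considered here, and "the series" means these few. Any claim that something is new, unique, unknown or untested is made for them only; others in the source may bear on it.

Compound 1 `O=C(NS(=O)(=O)c1ccc(F)cc1)c1ccc(Nc2nc(NC3(c4ccc(Cl)cc4)CC3)nc(OCC(F)(F)F)n2)cc1`: 193 nm/s in a physicochemical assay for permeability, using PAMPA, at pH 7.4; on this read-out lower numbers stand for lower permeability and higher numbers for higher permeability
Compound 2 `CC(C)(C)OC(=O)NCCS(=O)(=O)NC(=O)c1ccc(Nc2nc(NC3(c4ccc(Cl)cc4)CC3)nc(OCC(F)(F)F)n2)cc1`: 111 nm/s in this assay
Compound 3 `O=C(NS(=O)(=O)CCNC(=O)C1CC1)c1ccc(Nc2nc(NC3(c4ccc(Cl)cc4)CC3)nc(OCC(F)(F)F)n2)cc1`: 1 nm/s in this assay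

Of the compounds shown here, three sharing one core have been measured. Compound 3 stands lowest of the three in this assay: the distance from compound 2 to compound 3 is a 110-fold lower number from compound 2 to compound 3 (2.05 log units; beyond the scatter), and from compound 1 to compound 3 it is a 190-fold lower number from compound 1 to compound 3 (2.29 log units; beyond the scatter). By contrast the step from compound 1 to compound 2 is a 1.7-fold lower number from compound 1 to compound 2 (0.24 log units; within the scatter).

Compound 4 `CNC(=O)NCCS(=O)(=O)NC(=O)c1ccc(Nc2nc(NC3(c4ccc(Cl)cc4)CC3)nc(OCC(F)(F)F)n2)cc1` has not yet been measured. It differs from compound 3 in one place: methylamino in place of cyclopropyl on a carbonyl carbon. Among the measured compounds shown here, the only measured step at this same carbonyl carbon is the one from compound 2 to compound 3, which was a 110-fold lower number from compound 2 to compound 3 (2.05 log units; beyond the scatter), while the other two steps in the set sit on the sulfonyl sulfur. Compound 3 already gives a very low number, and the change to compound 4 swaps a small carbon ring for a group with a hydrogen-bond donor, so no recovery toward the numbers of compound 1 or compound 2 is expected; the number for compound 4 is expected to stay low, with the step of no change at the digits printed from compound 3 to compound 4 (within the scatter) as the estimate.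

Compound 4 is therefore estimated at 1 nm/s in this assay, within a range from 0.3 nm/s to 8 nm/s.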

Compound 4, apparent permeability: 40 nm/s
Beside the measured number, compound 4's estimate is 40-fold (1.60 log units) below it; the whole stated range lies below it.
By their numbers in this assay, from the lowest: compound 3; then compound 4; then compounds 2 and 1 (each within the scatter of the next).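

At this carbonyl carbon, the group attached matters greatly in this assay: swapping cyclopropyl for methylamino gives a 40-fold higher number from compound 3 to compound 4 (1.60 log units; beyond the scatter), so the very low number of compound 3 does not belong to every compound with this kind of side chain. Set against the two earlier compounds, the result is a 2.8-fold lower number from compound 2 to compound 4 (0.44 log units; beyond the scatter) and a 4.8-fold lower number from compound 1 to compound 4 (0.68 log units; beyond the scatter), both modest steps, which leaves compound 3 as the one that stands far below the rest of these four. No measurement shown here explains why this one small swap has so large an effect.

The compounds shown leave open whether the drop in compound 3 is tied to the cyclopropyl ring itself or to any plain carbon group on this carbonyl carbon, a question that a methyl or an isopropyl group there would address. They also leave open whether the hydrogen on the nitrogen of methylamino matters, which a dimethylamino group at the same place would test.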